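Swapping a Pyrrole for a Bromofuran in a Nitrile Series

A few compounds are considered here, and "the series" means these few. Any claim that something is new, unique, unknown or untested is made for them only; others in the source may bear on it.

Compounds measured so far:
compound 1, `N#C/C(=C\c1ccc(Cl)cc1)C(=O)c1ccc[nH]1`, 27000 nM
compound 2, `N#C/C(=C\c1ccc([N+](=O)[O-])cc1)C(=O)c1c[nH]c2ccccc12`, 35000 nM
compound 3, `COc1ccc(CNC(=O)/C(C#N)=C/c2ccc[nH]2)cc1`, 34000 nM

All three were tested in a functional assay on MCF7 cells (Homo sapiens) for inhibition, read by MTT assay, with a stated time of 72 h; a lower number here means a stronger inhibitor of growth, a higher number a weaker inhibitor of growth. The three numbers lie close together, each within the usual scatter of the others, so compound 3 sits among them without standing apart in either direction.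

Compound 4, `COc1ccc(CNC(=O)/C(C#N)=C/c2cc(Br)co2)cc1`, has not been measured in this assay. It differs from compound 3 in one place: 4-bromofuran-2-yl in place of 1H-pyrrol-2-yl on a double-bonded chain carbon bound to a double-bonded chain carbon. Among the compounds with values here, no measured pair shows the effect of such a change here, so there is nothing to anchor a direction. The expectation is a step from compound 3 to compound 4 of a 1.2-fold higher number from compound 3 to compound 4 (0.07 log units; within the scatter), that is, none beyond the scatter. Compound 4 is therefore estimated at 40000 nM, between 15000 nM and 110000 nM.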

Compound 4, concentration for 50% growth inhibition: 20000 nM
Estimate against measurement, compound 4: 2.0-fold (0.30 log units) above; the range from low to high includes it.
By their numbers in this assay, from the lowest: compounds 4, 1, 3 and 2 (each within the scatter of the next).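

Within the data shown here, this is the first pair to isolate a change at this position: in this assay, 4-bromofuran-2-yl in place of 1H-pyrrol-2-yl gives a 1.7-fold lower number from compound 3 to compound 4 (0.23 log units; within the scatter) and so shows no clear effect. The ring's hydrogen-bond donor can therefore go and a bromine can enter without a change beyond the scatter. Nothing measured here offers an explanation for this result.

The pair changes the ring and adds bromine together, so an unsubstituted furan-2-yl would be needed to separate the two. As far as these compounds go, what an amine or a carboxylic acid on this ring would do also remains open.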